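This account rests on a few compounds, and the source may have more. Where it says the series, first, only, none or still open, it means among the compounds named here.

Compound 3, with the structure `Cc1nc2c3ccccc3ccc2c2nc3c(ccc4ccccc43)c(-c3nccnc3N)c12`, gives 47.8 ug/mL in a functional assay, read by spectrophotometry, with a stated time of 15 min; on this read-out lower numbers stand for stronger inhibition and higher numbers for weaker inhibition. Two companions share its core and differ only in the group carried on one carbon of that core. Compound 1, `Cc1nc2c3ccccc3ccc2c2nc3c(ccc4ccccc43)c(-c3cccc([N+](=O)[O-])c3)c12`, gives 54.2 ug/mL in this assay, and compound 2, `Cc1nc2c3ccccc3ccc2c2nc3c(ccc4ccccc43)c(-c3cccnc3)c12`, gives 63.6 ug/mL. Every step between them is small: a 1.2-fold higher number from compound 1 to compound 2 (0.07 log units; within the scatter), a 1.1-fold lower number from compound 1 to compound 3 (0.05 log units; within the scatter) and a 1.3-fold lower number from compound 2 to compound 3 (0.12 log units; within the scatter). Compound 3 therefore stands within the scatter of both companions, and none of the three can be set apart from the others.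

Compound 4, `COc1ccc(-c2c3ccc4ccccc4c3nc3c2c(C)nc2c4ccccc4ccc32)cc1`, continues this series with the change (4-methoxyphenyl in place of 3-aminopyrazin-2-yl on an aromatic carbon). All three measured steps bear on it, since each also exchanged the group on that same carbon, and each stayed within the scatter. The expectation for compound 4 is therefore no step beyond the scatter in this assay, in either direction, which is to say a 1.1-fold higher number from compound 3 to compound 4 (0.04 log units; within the scatter). Compound 4 is expected to give about 52 ug/mL, with a likely range from 30 ug/mL to 90 ug/mL.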

Compound 4, half-maximal inhibitory concentration: 82.3 ug/mL
Compound 4: the middle estimate sits 1.6-fold (0.20 log units) below what was measured; the measured number falls inside the stated range.
By their numbers in this assay, from the lowest: compounds 3, 1, 2 and 4 (each within the scatter of the next).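

At this carbon of the shared core, 4-methoxyphenyl, an aromatic ring of carbon only, joins the other three groups without separating from them in this assay (a 1.7-fold higher number from compound 3 to compound 4 (0.24 log units; within the scatter); a 1.3-fold higher number from compound 2 to compound 4 (0.11 log units; within the scatter); a 1.5-fold higher number from compound 1 to compound 4 (0.18 log units; within the scatter)). Going by these compounds alone, the exchange for 3-aminopyrazin-2-yl removes the hydrogen-bond donor and the ring hetero atoms, something the earlier steps did not show alongside a carbon-only ring. Among these four compounds, then, neither that donor nor a ring nitrogen is needed for a number within the scatter of the others.

On these data alone, whether a carboxylic acid, a morpholine or a short alkyl chain at this carbon would move the number beyond the scatter remains open. No measurement shown explains why the four compounds stay so close.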